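This account rests on a few compounds, and the source may have more. Where it says the series, first, only, none or still open, it means among the compounds named here.

Measured compounds:
- compound 1 `S=C(N/N=C\c1ccc(Cl)cc1)NC1CCCCC1` gives 38300 nM in a functional assay on MDA-MB-231 cells (Homo sapiens) for inhibition, read by WST assay, with a stated time of 48 h; on this read-out lower numbers stand for stronger inhibition and higher numbers for weaker inhibition
- compound 2 `Oc1ccc(/C=N\NC(=S)NC2CCCCC2)cc1` gives 115000 nM in this assay

Going by the values given here, compound 2 stands at the highest of the two numbers recorded in this assay; its nearest neighbour is compound 1, and the single step recorded, a 3.0-fold higher number from compound 1 to compound 2 (0.48 log units; beyond the scatter), separates them.

The next compound, compound 3 `CCOc1ccc(/C=N\NC(=S)NC2CCCCC2)cc1`, is not yet measured. It differs from compound 2 by ethyl in place of hydrogen on an oxygen on an aromatic ring, that is, hydroxy to ethoxy on the aromatic ring.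

Among the compounds with values here, no measured step alters the hydroxy oxygen itself, so nothing recorded bears directly on this change. Within the data shown here, the only step available, a 3.0-fold higher number from compound 1 to compound 2 (0.48 log units; beyond the scatter), shows that exchanging the substituent at this aromatic position moves the number in this assay by a modest amount, and a step of about that size, in either direction, is the most that can be expected here; a change staying within the scatter is also plausible.

Compound 3 is therefore expected to give about 70000 nM in this assay, with a range from 25000 nM to 200000 nM. The step implied for compound 3 is an estimated 1.6-fold lower number from compound 2 to compound 3 (0.22 log units; within the scatter).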

Compound 3, half-maximal inhibitory concentration: 68200 nM
Beside the measured number, compound 3's estimate is 1.0-fold (0.01 log units) above it; the measured number falls inside the stated range.
By their numbers in this assay, from the lowest: compounds 1, 3 and 2 (each within the scatter of the next, the first and the last beyond it).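

In this assay, going by these compounds alone, ethyl on the oxygen on an aromatic ring is tolerated within the scatter, with a 1.7-fold lower number from compound 2 to compound 3 (0.23 log units; within the scatter), so this first change to the hydroxy oxygen itself gives no step that can be read as a real difference. Ethoxy also cannot be separated from chloro on the same aromatic carbon, with a 1.8-fold higher number from compound 1 to compound 3 (0.25 log units; within the scatter), so compound 3 overlaps both compound 1 and compound 2, even though a 3.0-fold higher number from compound 1 to compound 2 (0.48 log units; beyond the scatter) remains the only step beyond the scatter; the three compounds therefore do not give a clean ranking of these substituents, only a clear gap between the chloro and hydroxy end points. No supporting data are available to explain any of these steps.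

Still open, going by these compounds, is how a shorter methoxy group or a longer chain such as butoxy on the same oxygen would read in this assay, and how an amine or a carboxylic acid on that aromatic carbon would compare. The rest of the shared core is the same in all three compounds, so these results say nothing about changes made elsewhere in it.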